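A few compounds are considered here, and "the series" means these few. Any claim that something is new, unique, unknown or untested is made for them only; others in the source may bear on it.

Measured compounds:
- Compound 1 `CC1=CCC2C(CC[C@@]2(C)O)C(C)(C)C1CC[C@@H]1[C@@]2(C)CC[C@@H](O)C(C)(C)O[C@@H]2CC[C@]1(C)O`: in a functional assay on MDA-MB-231 cells (Homo sapiens) for antiproliferative activity, read by MTT assay, with a stated time of 72 h (a lower number here means a stronger inhibitor, a higher number a weaker inhibitor), compound 1 reaches only the limit > 50000 nM, so no number is known for it.
- Compound 2 `CC1=CC[C@H]2[C@H](CC[C@]2(C)O)C(C)(C)[C@@H]1CC[C@H]1[C@]2(C)CC[C@H](OC(=O)c3ccccc3)C(C)(C)O[C@H]2CC[C@@]1(C)O`: in this assay compound 2 gives 16100 nM.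
- Compound 3 `CC1=CC[C@H]2[C@@H]1CC=C(C)[C@@H](CC[C@H]1[C@]3(C)CC[C@H](OC(=O)c4ccccc4)C(C)(C)O[C@H]3CC[C@@]1(C)O)C2(C)C`: in this assay compound 3 gives 18400 nM.

Among the numbers shown, compound 2 and compound 3 sit within the usual scatter of each other, and the third value, that of compound 1, is a limit rather than a number, so no ordering among these three can be claimed. All three share a large core carrying an ester, and the ester end is where the next compound departs from compound 2.

Compound 4 `CC1=CC[C@H]2[C@H](CC[C@]2(C)O)C(C)(C)[C@@H]1CC[C@H]1[C@]2(C)CC[C@H](OC(=O)c3ccc(C(F)(F)F)c(F)c3)C(C)(C)O[C@H]2CC[C@@]1(C)O` keeps everything of compound 2 except the ring on the ester:

3-fluoro-4-(trifluoromethyl)phenyl in place of phenyl on a carbonyl carbon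

For the measured compounds named here, no pair of measured compounds differing in one place is available here, so there is no measured step to lean on. In this assay the step from compound 2 to compound 4 is expected to stay within the usual scatter, with no clear direction. Compound 4 is therefore estimated at 13000 nM, in a range from 4500 nM to 40000 nM, meaning a 1.2-fold lower number from compound 2 to compound 4 (0.09 log units; within the scatter).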

Compound 4, half-maximal inhibitory concentration: 22200 nM
Compound 4: middle estimate off by 1.7-fold (0.23 log units), on the low side; the measured number falls inside the stated range.
By their numbers in this assay, from the lowest: compounds 2, 3 and 4 (each within the scatter of the next). At a limit, above all of these: compound 1.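

In this assay, placing 3-fluoro-4-(trifluoromethyl)phenyl in place of phenyl on the carbonyl carbon gives a 1.4-fold higher number from compound 2 to compound 4 (0.14 log units; within the scatter). For the compounds shown here, this is the first reading of a change on this ring, and it shows that a clearly larger, fluorine-bearing group can stand there with no readable shift in either direction. Compound 1, which has a hydroxyl where compounds 2 and 4 hold the ester, stays at a limit and not a number: the limit of > 50000 nM in this assay, at which 1 of the 4 values shown sits.

Going by these compounds, the fluorine and the trifluoromethyl enter together, so what each does alone stays unknown. Also open, on these data alone, is how a pyridine ring, or a phenyl ring carrying an amine, would read in place of phenyl on the carbonyl carbon in this assay.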